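Swapping Bromine for Fluorine Beside a Nitro Group

The source may report more compounds than this note shows. Statements on the series, on what has been measured and on what is new or still open speak of the compounds shown alone.

Three compounds have been measured in an assay on HEK293 cells for displacement of a labelled ligand from metabotropic glutamate receptor 5 (Rattus norvegicus), read by scintillation counting; a higher number here means a weaker inhibitor, a lower number a stronger inhibitor:

Compound 1, `Cc1nc(C#Cc2cc(C#N)cc([N+](=O)[O-])c2)cs1`, gives 0.36 nM.
Compound 2, `Cc1nc(C#Cc2cc(Br)cc([N+](=O)[O-])c2)cs1`, gives 0.93 nM.
Compound 3, `Cc1nc(C#Cc2cc(Br)cc(C#N)c2)cs1`, gives 0.106 nM.

Compound 2 has the highest number of the three. Its neighbours sit below it: a 2.6-fold higher number from compound 1 to compound 2 (0.41 log units; beyond the scatter) runs upward to compound 2, and an 8.8-fold lower number from compound 2 to compound 3 (0.94 log units; beyond the scatter) runs downward from it. The third relation, a 3.4-fold lower number from compound 1 to compound 3 (0.53 log units; beyond the scatter), completes the picture, with compound 3 as the lowest of the set.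

Compound 4, `Cc1nc(C#Cc2cc(F)cc([N+](=O)[O-])c2)cs1`, differs from compound 2 in one place: fluoro in place of bromo on an aromatic carbon. Among the compounds with values here, none of the measured steps swaps one halogen for another; the steps that touch the bromo group compare it with cyano or with nitro, and each of those was modest. The data therefore give no direct guide for this change, only the observation that single-group swaps on this ring have so far moved this assay by modest amounts. A small step is expected, possibly within the scatter, with no firm direction.

Compound 4 is estimated at 1.5 nM, within a range of 0.5 nM to 5 nM, which means an expected step of a 1.6-fold higher number from compound 2 to compound 4 (0.21 log units; within the scatter).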

Compound 4, inhibition constant: 0.3 nM
For compound 4 the middle estimate is 5.0-fold (0.70 log units) above the measured one; the measured number lies below the stated range.
By their numbers in this assay, from the lowest: compound 3; then compounds 4 and 1 (each within the scatter of the next); then compound 2.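

The change of one halogen for another at this position is not a neutral swap in this assay: fluoro in place of bromo gives a 3.1-fold lower number from compound 2 to compound 4 (0.49 log units; beyond the scatter), the first step among these compounds to compare two halogens directly. With the nitro group kept, fluoro in place of cyano gives a 1.2-fold lower number from compound 1 to compound 4 (0.08 log units; within the scatter), so these two groups cannot be told apart here, while bromo stands apart from both with a higher number, beyond the scatter in each case. No measurement shown here offers an explanation for either step.

It remains open whether fluoro in place of bromo would bring a similar drop in the number when a nitrile takes the place of the nitro group, since compound 3 has the bromo and nitrile pair but no fluoro partner is shown. It is also unknown whether chloro, methyl or an amine on this aromatic carbon would fall with fluoro and cyano or with bromo, so a single halogen comparison gives no trend across the wider range of groups.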